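Replacing the dimethylaminobenzyl amide with a piperidinylmethyl amide

The source may report more compounds than this note shows. Statements on the series, on what has been measured and on what is new or still open speak of the compounds shown alone.

Measured so far:
compound 1 `O=C(NCc1ccncc1)c1cc(NS(=O)(=O)Cc2ccccc2)ccc1Sc1ccccc1` — > 30000 nM
compound 2 `CN(C)c1ccc(CNC(=O)c2cc(NS(=O)(=O)Cc3ccccc3)ccc2Sc2ccccc2)cc1` — > 30000 nM

In an assay on isolated protein for inhibition of Alpha-1B adrenergic receptor (Homo sapiens) (on this read-out lower numbers stand for stronger inhibition and higher numbers for weaker inhibition), compound 1 `O=C(NCc1ccncc1)c1cc(NS(=O)(=O)Cc2ccccc2)ccc1Sc1ccccc1` gives only the assay limit > 30000 nM. Compound 2 `CN(C)c1ccc(CNC(=O)c2cc(NS(=O)(=O)Cc3ccccc3)ccc2Sc2ccccc2)cc1` likewise returns the limit > 30000 nM. The step that the two limits leave unreadable from compound 1 to compound 2 is thus unreadable, both values resting at the limit of > 30000 nM in this assay, at which 2 of the 2 values shown sit. Compound 3 `O=C(NCC1CCNCC1)c1cc(NS(=O)(=O)Cc2ccccc2)ccc1Sc1ccccc1` differs from compound 2 by piperidin-4-yl in place of 4-(dimethylamino)phenyl on a saturated chain carbon bound to an amide-type nitrogen. Among the measured compounds shown here, no measured step bears on this change; the single step sits between two limits. Compound 3 is therefore expected to stay near the limit, the expected step being a step that the limit leaves unreadable from compound 2 to compound 3. The estimate for compound 3 is 40000 nM, in the range 8000 nM to 200000 nM.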

Compound 3, half-maximal inhibitory concentration: > 30000 nM
Compound 3: a limit, no number (the forecaster's own chance of this, stated with the estimate: 75%); the middle value is on the limit's open side.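

Compound 3, like compound 1 and compound 2, gives only a limit in this assay, so no step among the three can be read: the limit of > 30000 nM in this assay, at which 3 of the 3 values shown sit.

The compounds shown leave open whether any amide substituent on the shared core gives a measurable value.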